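A few compounds are considered here, and "the series" means these few. Any claim that something is new, unique, unknown or untested is made for them only; others in the source may bear on it.

Within the data shown here, in an in vitro ADME assay on microsomes from liver (Homo sapiens) for metabolic stability, read by LC-MS, tested at 1 uM (a lower number here means slower removal, a higher number faster removal of the compound), compound 1 (`COCCN(C)S(=O)(=O)c1ccc(C)c(C#Cc2cc(Cl)ccc2OCC(=O)O)c1`) gives 32 mL.min-1.g-1, the higher of the two numbers so far, while compound 2 (`CCCS(=O)(=O)c1ccc(F)c(C#Cc2cc(Cl)ccc2OCC(=O)O)c1`) gives 12 mL.min-1.g-1, a gap beyond the scatter. Compound 3 (`Cc1ccc(S(=O)(=O)N2CCCCC2C)cc1C#Cc1cc(Cl)ccc1OCC(=O)O`) has not yet been measured. It carries 2-methylpiperidin-1-yl in place of (2-methoxyethyl)(methyl)amino on a sulfonyl sulfur. Among the measured compounds shown here, no measured pair shows this change on its own, so the expectation rests on the structures alone. A moderate move towards faster removal is expected, an estimated 1.6-fold higher number from compound 1 to compound 3 (0.19 log units; within the scatter). In this assay the estimated number for compound 3 is 50 mL.min-1.g-1, with a range from 22 mL.min-1.g-1 to 110 mL.min-1.g-1.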

Compound 3, intrinsic clearance in microsomes: 89 mL.min-1.g-1
Beside the measured number, compound 3's estimate is 1.8-fold (0.25 log units) below it, and the stated range covers the measured number.
By their numbers in this assay, from the lowest: compound 2; then compound 1; then compound 3.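

In this assay, 2-methylpiperidin-1-yl in place of (2-methoxyethyl)(methyl)amino on a sulfonyl sulfur gives a 2.8-fold higher number from compound 1 to compound 3 (0.44 log units; beyond the scatter), the first single-place change available, and it shows that the group on this sulfur alone can shift the read-out beyond the scatter. The data offer no measured basis for explaining this step. On these data alone, what remains open is whether the ring or its methyl group carries the step, and what an unsubstituted piperidin-1-yl or a morpholin-4-yl on the same sulfur would give.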